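The compounds below may be only part of what the source reports. "The series", "measured", "known", "first", "only" and "open" are said of these compounds alone.

In a physicochemical assay for lipophilicity, at pH 7.4 (a lower number here means a more polar compound, a higher number a more lipophilic compound), compound 2 `CN(Cc1ccc2nccn2c1)c1nnc(-c2ccc(-c3ccccc3F)cc2)o1` gives 4.4 and compound 3 `COc1ccccc1-c1ccc(-c2nnc(N(C)Cc3ccc4nccn4c3)o2)cc1` gives 4.1, a gap that reads as a number 0.30 log units lower from compound 2 to compound 3 (within the scatter). Compound 1 `CN(Cc1ccc2nccn2c1)c1nnc(-c2ccc(C3CC3)cc2)o1` gives 3.5, and compound 2 stands clear of it, with a number 0.90 log units higher from compound 1 to compound 2 (beyond the scatter). The matching exchange gave a number 0.60 log units higher from compound 1 to compound 3 (beyond the scatter). Compound 4 `Cc1noc(C)c1-c1ccc(-c2nnc(N(C)Cc3ccc4nccn4c3)o2)cc1` keeps the core of compound 2 and carries 3,5-dimethyl-1,2-oxazol-4-yl in place of 2-fluorophenyl on an aromatic carbon. The entering group, unlike the leaving one, holds hydrogen-bond acceptors. Within the data shown here, no measured step puts such a ring at this place, so the modest steps above give only a rough size. A fall of similar size is expected, read as a number 0.70 log units lower from compound 2 to compound 4 (beyond the scatter). For compound 4 the estimated value is 3.7, with an expected range from 3.2 to 4.2.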

Compound 4, distribution coefficient: 3.1
Compound 4: middle estimate off by 0.60 log units, on the high side; measured number outside the range, below it.
By their numbers in this assay, from the lowest: compound 4; then compound 1; then compounds 3 and 2 (each within the scatter of the next).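

In this assay the 3,5-dimethyl-1,2-oxazol-4-yl ring, para to a large group, takes the number down from both substituted phenyl groups (a number 1.30 log units lower from compound 2 to compound 4 (beyond the scatter) and a number 1.00 log units lower from compound 3 to compound 4 (beyond the scatter)). It also lands under cyclopropyl (a number 0.40 log units lower from compound 1 to compound 4 (beyond the scatter)), which both phenyl groups stood above, so exchanges at this place can move the number in either direction from cyclopropyl. No measurement at hand accounts for the size of these steps. From the compounds shown here alone, what an amine or a carboxylic acid at this place would give stays open, as does the share of the two methyl groups on the entering ring.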